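Does Losing the Iodine Lift the Cytotoxicity Number?

The source may hold more compounds than are shown below. What is called first, only, known or untested is meant among the compounds shown, and "the series" means these compounds.

Of the compounds shown here, three that share one core have been tested in a functional assay on Vero cells (Chlorocebus sabaeus) for cytotoxicity; on this read-out higher numbers stand for lower toxicity in this test and lower numbers for higher toxicity in this test. Compound 1 (`Cc1cn(CC2(CO)CC2CO)c(=O)[nH]c1=O`), which carries a methyl group, gives > 500 ug/mL, and this is a limit of the assay, not a number. Compound 2 (`O=c1[nH]c(=O)n(CC2(CO)CC2CO)cc1/C=C/Cl`), which carries a 2-chloroethenyl group, gives > 500 ug/mL, again a limit. Within the data shown here, compound 3 (`O=c1[nH]c(=O)n(CC2(CO)CC2CO)cc1/C=C/I`), with its 2-iodoethenyl group, gives 330 ug/mL, the only true number of the three. The data so far are therefore marked by the limit of > 500 ug/mL in this assay, at which 2 of the 3 values shown sit.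

Compound 4 (`C#CCc1cn(CC2(CO)CC2CO)c(=O)[nH]c1=O`) has not been measured. It differs from compound 3 in one group: propargyl in place of 2-iodoethenyl on an aromatic carbon. In short, propargyl stands in place of 2-iodoethenyl on an aromatic carbon.

Among the measured compounds shown here, two measured steps bear on this change: an at least 1.5-fold lower number from compound 1 to compound 3 (0.18 log units; that floor lies within the scatter), and an at least 1.5-fold lower number from compound 2 to compound 3 (0.18 log units; that floor lies within the scatter). For the measured compounds named here, both lead to the only iodine-bearing compound, and compound 4 has no iodine, so the same kind of step is expected in reverse, towards a higher number in this assay. Its size is hard to read from floors alone. The expected step is a 1.5-fold higher number from compound 3 to compound 4 (0.18 log units; within the scatter), a modest one. For compound 4 the estimated value is 500 ug/mL, with an expected range from 270 ug/mL to 950 ug/mL.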

Compound 4, half-maximal cytotoxic concentration: > 500 ug/mL
Compound 4 ended at the assay's limit; the forecaster's own chance of this, stated with the estimate: 60%; the middle value sits exactly at the limit.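

In this assay, compound 4 gives > 500 ug/mL, which is a limit of the assay and not a true number. Placing an all-carbon propargyl chain with a triple bond on this aromatic carbon gives an at least 1.5-fold higher number from compound 3 to compound 4 (0.18 log units; that floor lies within the scatter), so a group without iodine and unlike the earlier methyl and 2-chloroethenyl groups also reaches the limit, leaving compound 3, the only iodine-bearing compound, as the exception among the four. The steps from compound 1 and compound 2 to compound 4 cannot be read, and the comparison at this position is held back by one feature of the data: the limit of > 500 ug/mL in this assay, at which 3 of the 4 values shown sit.

The compounds shown leave open whether the number of compound 3 is tied to iodine itself or to the whole 2-iodoethenyl group, a question that a 2-bromoethenyl group or a plain iodo group on the same carbon could help to settle. They also leave open how far the compounds at the limit differ from one another, and whether a longer chain or an amine at this position would stay at the limit.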